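Thioether series: from compound 1 to compound 4

This account rests on a few compounds, and the source may have more. Where it says the series, first, only, none or still open, it means among the compounds named here.

Values in a functional assay on SMMC-7721 cells (Homo sapiens) for antiproliferative activity, read by CCK-8 assay, with a stated time of 72 h; a higher number here means a weaker inhibitor, a lower number a stronger inhibitor:
- compound 1 `CCc1ccc(SCc2ccc(/C=C/C(=O)Nc3ccccc3N)cc2)cc1`: "not determined" (no result reported)
- compound 2 `COc1ccc(SCc2ccc(C(=O)Nc3ccccc3N)cc2)cc1`: 2170 nM
- compound 3 `Cc1ccc(SCc2ccc(C(=O)Nc3ccccc3N)cc2)cc1`: 3740 nM

In this assay compound 1 stands at "not determined" (no result reported), so the starting point has no number. Compound 4 `Nc1ccccc1NC(=O)/C=C/c1ccc(CSCCc2ccccc2)cc1` carries phenethyl in place of 4-ethylphenyl on a sulfur. Within the data shown here, the only measured step, a 1.7-fold higher number from compound 2 to compound 3 (0.24 log units; within the scatter), involves other groups, is small and gives no guide to this change. Among the measured compounds shown here, no step from compound 1 can therefore be expected in size or direction. The nearest anchors are compound 2 at 2170 nM and compound 3 at 3740 nM, though the core of compound 1 differs from theirs. The expected value for compound 4 is 2500 nM, with an estimated range of 700 nM to 9000 nM.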

Compound 4, half-maximal inhibitory concentration: 10900 nM
Compound 4: the middle estimate sits 4.4-fold (0.64 log units) below what was measured; measured number outside the range, above it.
By their numbers in this assay, from the lowest: compounds 2 and 3 (each within the scatter of the next); then compound 4.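

In this assay, among these compounds, compound 1 gives "not determined" (no result reported) and compound 4 gives 10900 nM so no step between them can be read. The compounds shown leave open what phenethyl in place of 4-ethylphenyl on a sulfur does to the number. No supporting data bear on this result.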